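This account rests on a few compounds, and the source may have more. Where it says the series, first, only, none or still open, it means among the compounds named here.

In an ADME assay on BaF3 cells (Mus musculus) for antiproliferative activity, read by CCK-8 assay, with a stated time of 72 h (a higher number here means a weaker inhibitor of growth, a lower number a stronger inhibitor of growth), compound 1 `Cc1cccc(NC(=O)CCSc2ccc3c(/C=C/c4ccccn4)n[nH]c3c2)c1` returns > 10000 nM as a limit of the assay and not a number. Compound 2 `O=C(NCCSc1ccc2c(/C=C/c3ccccn3)n[nH]c2c1)c1cccc(C(F)(F)F)c1` gives 1500 nM and compound 3 `O=C(NCCSc1ccc2c(/C=C/c3ccccn3)n[nH]c2c1)Nc1cccc(C(F)(F)F)c1` stands at 3000 nM with the two values close together. Compound 4 `CN1CCN(Cc2ccc(NC(=O)NCCSc3ccc4c(/C=C/c5ccccn5)n[nH]c4c3)cc2C(F)(F)F)CC1` carries one change (4-methylpiperazin-1-yl)methyl in place of hydrogen on an aromatic carbon with (4-methylpiperazin-1-yl)methyl in place of hydrogen on an aromatic carbon, ortho to a trifluoromethyl group. Among the measured compounds shown here, the only measured step is a 2.0-fold higher number from compound 2 to compound 3 (0.30 log units; within the scatter) and it swaps the group on a carbonyl carbon, so it gives no size for this addition. A step to a lower number is tentatively expected, estimated as a 5.0-fold lower number from compound 3 to compound 4 (0.70 log units; beyond the scatter) with wide uncertainty. Compound 4 is expected near 600 nM (from 60 nM to 4000 nM).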

Compound 4, concentration for 50% growth inhibition: 3100 nM
The estimate for compound 4 lay 5.2-fold (0.71 log units) below the measured number; measured number inside the range.
By their numbers in this assay, from the lowest: compounds 2, 3 and 4 (each within the scatter of the next, the first and the last beyond it). At a limit, above all of these: compound 1.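

In this assay, the step with (4-methylpiperazin-1-yl)methyl in place of hydrogen, on the aromatic carbon ortho to a trifluoromethyl group, is a 1.0-fold higher number from compound 3 to compound 4 (0.01 log units; within the scatter). This position therefore accepts this large ring-bearing group, and the two compounds cannot be told apart by their numbers. Nothing given here bears on why this step is so small.

As far as these compounds go, whether a morpholin-4-ylmethyl group, a simple amine or a carboxylic acid on the same carbon would give a different number stays open. So does the outcome of this addition on compound 2.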